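Chloro in place of isopropoxy: expected potency of compound 3

This account rests on a few compounds, and the source may have more. Where it says the series, first, only, none or still open, it means among the compounds named here.

Compound 1 `COc1cc(-n2ncnc2-c2ccc(OC(C)C)cc2)cc(OC)c1OC` is the reference point. In a functional assay on A549 cells (Homo sapiens) for antiproliferative activity, read by MTT assay, with a stated time of 72 h (on this read-out lower numbers stand for stronger inhibition and higher numbers for weaker inhibition), compound 1 gives only a limit, > 10000 nM. Compound 2 `COc1cc(-c2ncnn2-c2ccc(Cl)c(Cl)c2)cc(OC)c1OC` is the other measured member of the pair. In this assay compound 2 likewise gives only a limit, > 10000 nM. Among the measured compounds shown here, both values sit at the limit of > 10000 nM in this assay, at which 2 of the 2 values shown sit, so compound 1 stands without a number of its own, level with the sole other measured compound. Compound 3 `COc1cc(-n2ncnc2-c2ccc(Cl)cc2)cc(OC)c1OC` carries the change (chloro in place of isopropoxy on an aromatic carbon). For the measured compounds named here, no step between measured compounds is available. Compound 3 is estimated at 15000 nM, within 5000 nM to 50000 nM, most likely again as a limit. The step that the limit leaves unreadable from compound 1 to compound 3 is expected to be none beyond the scatter.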

Compound 3, half-maximal inhibitory concentration: > 10000 nM
Compound 3: a limit, no number (the forecaster's own chance of this, stated with the estimate: 75%); the middle value does not contradict the limit.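

No step from compound 1 to compound 3 can be read, as both give only a limit in this assay: the limit of > 10000 nM in this assay, at which 3 of the 3 values shown sit.

The compounds shown leave open how chloro and isopropoxy compare in this assay, and which change to the shared core would give a measurable value.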